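Notes on removing the amino link from the carbonyl

The compounds below may be only part of what the source reports. "The series", "measured", "known", "first", "only" and "open" are said of these compounds alone.

Measured in a functional assay on CAKI-1 cells (Homo sapiens) for inhibition, read by sulforhodamine B assay, with a stated time of 48 h, tested at 0.1 uM; a lower number here means a stronger effect, a higher number a weaker effect of the compound at the concentration tested:
compound 1 `COc1cc(Cl)cc(-c2nn(-c3cccc(NC(=O)Nc4ccc(Cl)c(C(F)(F)F)c4)c3)cc2-c2ccncc2)c1`: 99%
compound 2 `COc1cc(Cl)cc(-c2nn(-c3cccc(NC(=O)Nc4ccc(Cl)c(Cl)c4)c3)cc2-c2ccncc2)c1`: 102%
compound 3 `COc1cc(Cl)cc(-c2nn(-c3cccc(NC(=O)Nc4cccc(C(F)(F)F)c4)c3)cc2-c2ccncc2)c1`: 104%

All three compounds sit close together in this assay. Compound 3 holds the highest of the three numbers, but the gap to its nearest neighbour is a number 2 percentage points higher from compound 2 to compound 3 (within the scatter) and the gap to the furthest is a number 5 percentage points higher from compound 1 to compound 3 (within the scatter), both within the scatter, so no order among compounds 1, 2 and 3 can be read from these numbers. The remaining pair also moves little: a number 3 percentage points higher from compound 1 to compound 2 (within the scatter).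

Compound 4 `COc1cc(Cl)cc(-c2nn(-c3cccc(NC(=O)c4cccc(C(F)(F)F)c4)c3)cc2-c2ccncc2)c1` is the next member. Against compound 3 the difference is 3-(trifluoromethyl)phenyl in place of (3-(trifluoromethyl)phenyl)amino on a carbonyl carbon.

Going by the values given here, none of the measured steps touches the carbonyl or its neighbouring amide-type nitrogen; each of them exchanges substituents on the distal aromatic ring only, and each stays within the scatter. Among the compounds with values here, there is therefore no measured step that bears directly on this change, and nothing in the three numbers suggests that the linker matters at this concentration. The expectation is thus a step of a number 4 percentage points lower from compound 3 to compound 4 (within the scatter), that is, none beyond the scatter. Compound 4 is estimated at 100% in this assay, within a range from 88% to 110%.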

Compound 4, a percentage reported as activity, at one concentration (the size of the read-out at that concentration, not a potency): 94%
For compound 4 the middle estimate is 6 percentage points above the measured one; the range from low to high includes it.
By their numbers in this assay, from the lowest: compounds 4, 1, 2 and 3 (each within the scatter of the next).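

Placing 3-(trifluoromethyl)phenyl directly on the carbonyl carbon is the first exchange shown at this position rather than on the distal aromatic ring, and it removes the nitrogen with its hydrogen-bond donor; in this assay, the step reads a number 10 percentage points lower from compound 3 to compound 4 (within the scatter). The two other steps that reach the same compound, a number 8 percentage points lower from compound 2 to compound 4 (within the scatter) and a number 5 percentage points lower from compound 1 to compound 4 (within the scatter), also stay within the scatter, so all three comparisons show that the amino link can be removed without a readable change in this read-out at the concentration tested. No independent measurement bears on this result.

The compounds shown leave open whether the carbonyl itself matters at this position, for instance whether a sulfonyl group in its place, or a longer chain carrying the 3-(trifluoromethyl)phenyl group on the carbonyl carbon, would also stay within the scatter. With all four compounds close together at one concentration, they also leave open whether the amino link would matter under conditions where these compounds separate in this assay.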